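Enlarging a Methyl to Cyclopropyl Beside the Ring Nitrogen

This account rests on a few compounds, and the source may have more. Where it says the series, first, only, none or still open, it means among the compounds named here.

In a functional assay on V79-379A cells (Cricetulus griseus) for cytotoxicity, read by MTT assay, in the presence of a further agent that is not named here (on this read-out lower numbers stand for stronger inhibition and higher numbers for weaker inhibition), compound 1 `COC1=CC(=O)c2c(c(COC(=O)c3ccccc3)cn2C)C1=O` gives 1400 nM, while compound 2 `COC1=CC(=O)c2c(c(COC(=O)c3ccccc3)c(C)n2C)C1=O` gives 16000 nM, the higher of the two numbers; that single change, an 11-fold higher number from compound 1 to compound 2 (1.06 log units; beyond the scatter). Compound 3 `COC1=CC(=O)c2c(c(COC(=O)c3ccccc3)c(C3CC3)n2C)C1=O` differs from compound 2 by cyclopropyl in place of methyl on an aromatic carbon, on the aromatic carbon next to the ring nitrogen. Among the compounds with values here, the only step that speaks to this spot is the large one from compound 1 to compound 2, so a further enlargement is expected to weaken or at best hold. Compound 3 is therefore estimated at 30000 nM in this assay, within 8000 nM to 100000 nM, meaning a 1.9-fold higher number from compound 2 to compound 3 (0.27 log units; within the scatter).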

Compound 3, half-maximal inhibitory concentration: 198000 nM
Compound 3: the middle estimate sits 6.6-fold (0.82 log units) below what was measured, outside the stated range (above it).
By their numbers in this assay, from the lowest: compound 1; then compound 2; then compound 3.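

Enlarging methyl to cyclopropyl on this aromatic carbon gives a 12-fold higher number from compound 2 to compound 3 (1.09 log units; beyond the scatter) in this assay and so the weakening seen with methyl does not level off at the larger group. Measured against hydrogen, cyclopropyl gives a 140-fold higher number from compound 1 to compound 3 (2.15 log units; beyond the scatter) and among these three compounds the number rises with each larger group at this spot. Nothing available explains why the number rises at this position. On these data alone, whether an amine, a carboxylic acid or a longer chain such as propyl on this carbon would continue the same rise remains open.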